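Trimming a Side Chain: From Compound 1 to Compound 4

A few compounds are considered here, and "the series" means these few. Any claim that something is new, unique, unknown or untested is made for them only; others in the source may bear on it.

Of the compounds shown here, three have been measured so far in a functional assay on HEp-2 cells (Homo sapiens) for inhibition; a higher number here means a weaker inhibitor, a lower number a stronger inhibitor. Compound 1, with the structure `CCC(C)C1NC(=O)N(C2CCCCC2)C1=O`, gives 69700 nM in this assay. Compound 3, with the structure `O=C1NC(c2ccccc2)C(=O)N1Cc1ccccc1`, gives 82900 nM in this assay, a number so close to that of compound 1 that the two cannot be told apart within the usual scatter of repeated measurements. Compound 2, with the structure `CCC(C)C(NC(=O)n1nnc2ccccc21)C(=O)NCc1ccccc1`, is reported in this assay only as a limit, > 100000 nM, and that is the limit of > 100000 nM in this assay, at which 1 of the 3 values shown sits. Among the compounds with values here, of the two actual numbers, compound 1 has the lower one, yet no compound here stands apart beyond the scatter.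

Compound 4, with the structure `CC(C)C1NC(=O)N(C2CCCCC2)C1=O`, keeps the core of compound 1 and differs from it in a single place: hydrogen in place of methyl on a saturated chain carbon, two bonds along the chain from a saturated ring carbon. Within the data shown here, no pair of measured compounds differs by exactly this change, so the size of the step has to be judged without a direct precedent. Removing one methyl from a short side chain is expected to move the number only a little, and if anything towards a weaker inhibitor. The step from compound 1 to compound 4 is expected to be a 1.3-fold higher number from compound 1 to compound 4 (0.11 log units; within the scatter), within or only just beyond the scatter. Compound 4 is therefore estimated at 90000 nM, with a range from 40000 nM to 200000 nM.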

Compound 4, half-maximal inhibitory concentration: 100000 nM
Estimate against measurement, compound 4: 1.1-fold (0.05 log units) below; the range from low to high includes it.
By their numbers in this assay, from the lowest: compounds 1, 3 and 4 (each within the scatter of the next).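

Within the data shown here, this is the only step in this assay that changes a single place, so the change from sec-butyl to isopropyl can now be read directly rather than judged without a precedent: a 1.4-fold higher number from compound 1 to compound 4 (0.16 log units; within the scatter). A step of this size cannot be told apart from the differences seen between repeated measurements, so at this position the assay does not separate the two side chains, and removing this one methyl has no effect that can be claimed. Compound 2 is reported only as a limit and not as a number, so it adds no step to this comparison: the limit of > 100000 nM in this assay, at which 1 of the 4 values shown sits.

The compounds shown leave open whether a larger change at this same place on the shared core, such as a longer chain, an amine or a carboxylic acid in place of the sec-butyl group, would move the number beyond the scatter. As far as these compounds go, they also rest on a single step with a single cyclohexyl-bearing core, so whether hydrogen in place of methyl on this chain would behave the same way on another core remains unknown.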